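Widening the Ether on the Aryl Ring of Compound 1

This account rests on a few compounds, and the source may have more. Where it says the series, first, only, none or still open, it means among the compounds named here.

Compound 1 `COc1cccc(-c2nc3ccc(C)cn3c2NC2CCCCC2)c1` stands as the stronger of the two measured compounds in an assay on S100 cells for inhibition of Polyunsaturated fatty acid 5-lipoxygenase (Homo sapiens), read by HPLC, with stated times of 15 min and 10 min (on this read-out higher numbers stand for weaker inhibition and lower numbers for stronger inhibition), where compound 1 gives 430 nM. The other measured compound, compound 2 `Cc1ccc2nc(-c3ccccc3O)c(NC3CCCCC3)n2c1`, gives 1800 nM; the step of a 4.2-fold higher number from compound 1 to compound 2 (0.62 log units; beyond the scatter) accompanied a 2-hydroxyphenyl in place of the 3-methoxyphenyl. Compound 3 `Cc1ccc2nc(-c3cccc(Oc4ccccc4)c3)c(NC3CCCCC3)n2c1` differs from compound 1 by phenyl in place of methyl on an oxygen on an aromatic ring. Within the data shown here, no measured step alters what sits on that oxygen, so the single measured step bears only loosely on this change. The expected step from compound 1 to compound 3 is a 1.4-fold higher number from compound 1 to compound 3 (0.14 log units; within the scatter), within the scatter. Compound 3 is therefore estimated at 600 nM, with a range from 200 nM to 2000 nM.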

Compound 3, half-maximal inhibitory concentration: 50 nM
Beside the measured number, compound 3's estimate is 12-fold (1.08 log units) above it, and the stated range ends above it.
By their numbers in this assay, from the lowest: compound 3; then compound 1; then compound 2.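

The step from compound 1 to compound 2 changed both the group on the aryl ring and where it sits; here only what sits on the oxygen changes, and phenyl in place of methyl gives an 8.6-fold lower number from compound 1 to compound 3 (0.93 log units; beyond the scatter) in this assay for this change. This oxygen therefore carries a whole phenyl ring with stronger inhibition, not a loss. Nothing available explains this gain. Still open, on these data alone, is how a benzyl group, a longer chain such as butyl, or a phenyl ring bearing an amine would fare on the same oxygen.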